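A few compounds are considered here, and "the series" means these few. Any claim that something is new, unique, unknown or untested is made for them only; others in the source may bear on it.

Three compounds sharing a chlorinated fused core have been examined in a functional assay on CAKI-1 cells (Homo sapiens) for cytotoxicity, read by sulforhodamine B assay, with a stated time of 48 h; a higher number here means that more compound is tolerated, a lower number that less compound is tolerated. Compound 1 `ClCc1ccc(Cn2cnc3c(Cl)ncnc32)cc1` gives 2390 nM in this assay. Compound 2 `ClCc1ccc(Cn2cnc3nc(Cl)nc(Cl)c32)cc1` gives 5370 nM, and compound 3 `ClCc1ccc(Cn2cnc3c(Cl)nc(Cl)nc32)cc1` gives 46800 nM. Compound 2 therefore stands second highest of the three: its number lies above that of compound 1 and below that of compound 3, and the values show both separations to be beyond the scatter. How the core of compound 2 differs from that of compound 3 is not broken down here.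

Compounds 3 and 1 differ in a single place, (hydrogen in place of chloro on an aromatic carbon), and this change made a large step, a 20-fold lower number from compound 3 to compound 1 (1.29 log units; beyond the scatter).

Compound 4 `ClCc1ccc(Cn2cnc3ncnc(Cl)c32)cc1` has not yet been measured. It differs from compound 2 by hydrogen in place of chloro on an aromatic carbon. The surroundings of the place are described in the same words for both pairs, so this is the same change that separates compound 3 from compound 1. The step from compound 2 to compound 4 is expected to be a 12-fold lower number from compound 2 to compound 4 (1.08 log units; beyond the scatter), somewhat smaller than the earlier one, because it rests on a single observed instance, a 20-fold lower number from compound 3 to compound 1 (1.29 log units; beyond the scatter), and a second occurrence of a change need not repeat the full size of the first. Compound 4 is accordingly expected to give about 450 nM in this assay, with a range from 120 nM to 1800 nM.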

Compound 4, concentration lethal to 50% of the cells: 9770 nM
The estimate for compound 4 lay 22-fold (1.34 log units) below the measured number; the whole stated range lies below it.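

In this assay, going by these compounds alone, hydrogen in place of chloro on an aromatic carbon between two ring nitrogen atoms gave a 1.8-fold higher number from compound 2 to compound 4 (0.26 log units; within the scatter), so on the core of compound 2 this exchange produced no step that can be told from the scatter. The result shows that the large step seen on the core of compound 3 cannot simply be carried over to the core of compound 2, yet two pairs give no rule for any further core and do not reveal what sets the two cores apart. Placed side by side, the two steps do not agree in size, and the gap between them exceeds what repeated measurement would explain: the same change on two cores in this assay, a 20-fold lower number (1.29 log units; beyond the scatter) from compound 3 to compound 1 and a 1.8-fold higher number (0.26 log units; within the scatter) from compound 2 to compound 4, 36-fold (1.55 log units) apart, beyond the scatter of two such steps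

The compounds shown carry only chloro or hydrogen at this place, so it remains open how an amine, a methoxy group or a longer chain there would read in this assay on either core. All four compounds also share the chloromethyl group on the benzyl side chain, which leaves open whether the two cores would still answer differently to this exchange with a hydroxymethyl group or an unsubstituted benzyl group in its place.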